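Lengthening a Side Chain from Compound 1 to Compound 4

The compounds below may be only part of what the source reports. "The series", "measured", "known", "first", "only" and "open" are said of these compounds alone.

Among the measured compounds shown here, in a functional assay on COLO 205 cells (Homo sapiens) for cytotoxicity, read by MTT assay, with a stated time of 24 h (a lower number here means a stronger inhibitor, a higher number a weaker inhibitor), compound 1 `CCCCCCCCCCn1cc(-c2nc3ccccc3cc2C)nn1` gives 44.5 ug/mL as the only true number so far. Compound 2 `CCCCCCCCCCn1cc(-c2nc3ccccc3cc2CCC)nn1` reads > 100 ug/mL as a limit of the assay, not a number. Compound 3 `CCCCCc1cc2ccccc2nc1-c1cn(CCC(F)(F)C(F)(F)C(F)(F)C(F)(F)C(F)(F)C(F)(F)C(F)(F)C(F)(F)F)nn1` reads > 100 ug/mL as a limit too.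

Compound 4 `CCCCCCCCCCn1cc(-c2nc3ccccc3cc2CCCCC)nn1` is still unmeasured. It differs from compound 1 by butyl in place of hydrogen on a saturated chain carbon bound to an aromatic carbon in one place: butyl in place of hydrogen on a saturated chain carbon bound to an aromatic carbon, which reads as methyl to pentyl. The nearest measured change, ethyl in place of hydrogen on such a carbon, gave an at least 2.2-fold higher number from compound 1 to compound 2 (0.35 log units; beyond the scatter) and lies beyond the scatter. From the compounds shown here alone, it ends at a limit, so its full size stays unknown. Butyl is the larger addition, so a step the same way, toward a weaker inhibitor, is expected, and compound 4 may well reach the limit of > 100 ug/mL in this assay, at which 2 of the 3 values shown sit, too. The expected step is a 2.7-fold higher number from compound 1 to compound 4 (0.43 log units; beyond the scatter) by this estimate. Compound 4 is estimated at 120 ug/mL with an expected range from 60 ug/mL to 250 ug/mL if a number is reported at all.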

Compound 4, half-maximal inhibitory concentration: > 100 ug/mL
Compound 4 ended at the assay's limit; the forecaster's own chance of this, stated with the estimate: 75%; the middle value is on the limit's open side.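

In this assay, butyl in place of hydrogen on a saturated chain carbon bound to an aromatic carbon gives an at least 2.2-fold higher number from compound 1 to compound 4 (0.35 log units; beyond the scatter). Compound 4 stands at a limit of the assay, not at a number. Compound 2 and compound 4 thus both point the same way from compound 1, so pentyl gives a second case of a longer chain at this place moving toward a weaker inhibitor, and the step between compound 2 and compound 4 cannot be read, leaving the effect of further lengthening unknown: the limit of > 100 ug/mL in this assay, at which 3 of the 4 values shown sit.

Still open, from the compounds shown here alone, is whether an ethyl chain at this place would stay near compound 1, at 44.5 ug/mL. Going by these compounds, it is equally open whether an amine or a carboxylic acid on this chain would give a readable number, rather than another limit.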